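A 2,6-dichlorophenyl swap on a sulfonyl sulfur

The source may report more compounds than this note shows. Statements on the series, on what has been measured and on what is new or still open speak of the compounds shown alone.

In an ADME assay on MT4 cells (Homo sapiens) for cytotoxicity, read by MTT assay (on this read-out lower numbers stand for higher toxicity in this test and higher numbers for lower toxicity in this test), compound 3 `Cc1cccc(C)c1S(=O)(=O)c1c(C(=O)NCc2ccncc2)[nH]c2ccc(Cl)cc12` gives only a limit, > 55000 nM, and no exact number. Compound 1 `Cc1cccc(C)c1S(=O)(=O)c1c(C(N)=O)[nH]c2ccc(Cl)cc12` likewise gives only a limit, > 48900 nM. Thus (pyridin-4-yl)methyl in place of hydrogen on an amide-type nitrogen yields a step that the two limits leave unreadable from compound 1 to compound 3, and this step offers no usable size. Compound 2 `NC(=O)c1[nH]c2ccc(Cl)cc2c1S(=O)(=O)c1c(Cl)cccc1Cl`, by contrast, gives a measured 16000 nM.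

Compound 4 `O=C(NCc1ccncc1)c1[nH]c2ccc(Cl)cc2c1S(=O)(=O)c1c(Cl)cccc1Cl` differs from compound 3 by one exchange: 2,6-dichlorophenyl in place of 2,6-dimethylphenyl on a sulfonyl sulfur. The same exchange, 2,6-dichlorophenyl in place of 2,6-dimethylphenyl on a sulfonyl sulfur, has been measured once, as an at least 3.0-fold lower number from compound 1 to compound 2 (0.48 log units; beyond the scatter). On that single pair, a step of at least modest size towards a lower number, beyond the scatter, is expected in this assay. The estimate amounts to an expected at least 3.0-fold lower number from compound 3 to compound 4 (0.48 log units; beyond the scatter). Compound 4 is expected at about 18000 nM, with an estimated range of 6000 nM to 55000 nM.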

Compound 4, half-maximal cytotoxic concentration: > 50200 nM
Compound 4: no number, only a limit; the forecaster's own chance of this, stated with the estimate: 20%; middle value at least 2.7-fold (0.44 log units) away from the limit.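

Compound 4 gives only a limit and no number: the limit of > 50200 nM in this assay, at which 1 of the 4 values shown sits.

With 2,6-dichlorophenyl on the sulfonyl sulfur, (pyridin-4-yl)methyl in place of hydrogen on the amide-type nitrogen now has a readable size, as an at least 3.1-fold higher number from compound 2 to compound 4 (0.49 log units; beyond the scatter), whereas with 2,6-dimethylphenyl the same exchange could not be read. The steps between limits, including the 2,6-dichlorophenyl swap between compound 3 and compound 4, cannot be read, so among these compounds only compound 2 carries a measured number.

On these data alone, how far the limited values lie from their limits stays open, and with it the true size of the swap when (pyridin-4-yl)methyl is present. Also open, as far as these compounds go, is whether another group on the amide-type nitrogen, such as a longer chain ending in an amine or a carboxylic acid, would shift the number from that of compound 2 in the same direction.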